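The source may hold more compounds than are shown below. What is called first, only, known or untested is meant among the compounds shown, and "the series" means these compounds.

Measured compounds:
compound 1, `Cn1nccc1-c1cc(C(F)(F)F)ccc1[C@H]1CCOc2cc(S(=O)(=O)Nc3ccncn3)ccc21`, 1180000 nM
compound 2, `O=S(=O)(Nc1ccncn1)c1ccc2c(c1)OCC[C@@H]2c1ccc(C(F)(F)F)cc1-c1ccc(F)cn1`, 181000 nM
compound 3, `Cc1ccc(-c2cc(C(F)(F)F)ccc2[C@H]2CCc3cc(S(=O)(=O)Nc4ncccn4)ccc32)cn1`, 47000 nM

In a physicochemical assay for solubility (on this read-out higher numbers stand for higher solubility and lower numbers for lower solubility), compound 1 stands highest of the three; compound 2 lies nearest, and compound 3 furthest, both beyond the scatter. Within the data shown here, the only single change among the measured compounds is a 6.5-fold lower number from compound 1 to compound 2 (0.81 log units; beyond the scatter), which concerns a different part of the molecule.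

Compound 4, `Cn1nccc1-c1cc(C(F)(F)F)ccc1[C@H]1CCOc2cc(S(=O)(=O)Nc3ncccn3)ccc21`, keeps every other part of compound 1 and differs in one place: pyrimidin-2-yl in place of pyrimidin-4-yl on a sulfonamide nitrogen. Among the measured compounds shown here, no measured step bears on this change. Compound 3 also carries pyrimidin-2-yl on its sulfonamide nitrogen, but it differs from compound 1 in more than one place. In this assay compound 3 gives 47000 nM, which can only show that such a compound can sit well below compound 1, without saying how much of that gap belongs to the pyrimidine. For the measured compounds named here, with no direct precedent, compound 4 is expected to change by a 1.7-fold lower number from compound 1 to compound 4 (0.23 log units; within the scatter), within the scatter, though the range is wide. Compound 4 is therefore estimated at 700000 nM, between 200000 nM and 2500000 nM.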

Compound 4, solubility: 532000 nM
The estimate for compound 4 lay 1.3-fold (0.12 log units) above the measured number, and the stated range covers the measured number.
By their numbers in this assay, from the lowest: compound 3; then compound 2; then compound 4; then compound 1.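

With the rest of the molecule held fixed, pyrimidin-2-yl in place of pyrimidin-4-yl on the sulfonamide nitrogen gives a 2.2-fold lower number from compound 1 to compound 4 (0.35 log units; beyond the scatter) in this assay, so this position registers an exchange between two groups with the same heavy-atom, donor and acceptor counts. Among these compounds, this is the first measured step at this position, modest in size, and it is known only for compounds carrying 1-methyl-1H-pyrazol-5-yl. Nothing given here explains why the two pyrimidines differ.

As far as these compounds go, whether the same step would appear with 5-fluoropyridin-2-yl in place of 1-methyl-1H-pyrazol-5-yl remains open, and so does the share of the pyrimidine in the lower number of compound 3. Also open, from the compounds shown here alone, is how a pyridin-2-yl or thiazol-2-yl group on the sulfonamide nitrogen would read in this assay against either pyrimidine.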